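A few compounds are considered here, and "the series" means these few. Any claim that something is new, unique, unknown or untested is made for them only; others in the source may bear on it.

In a functional assay on HeLa cells (Homo sapiens) for antiproliferative activity, read by MTT assay, with a stated time of 48 h (a higher number here means a weaker inhibitor, a lower number a stronger inhibitor), the measured compounds read as follows:

Compound 1 (`C=C(c1cc(OC)c(OC)c(OC)c1)c1ccc(OC)cc1NC(=O)CNCC`): 430 nM
Compound 2 (`C=C(c1cc(OC)c(OC)c(OC)c1)c1ccc(OC)c(O)c1NC(C)=O`): 90 nM

Compound 2 holds the lower of the two numbers, and compound 1 lies above it by more than the scatter. Compound 3 (`C=C(c1cc(OC)c(OC)c(OC)c1)c1ccc(OC)c(O)c1NC(=O)CO`) departs from compound 2 by one change (hydroxy in place of hydrogen on a saturated chain carbon bound to a carbonyl carbon), hydroxy in place of hydrogen on a saturated chain carbon bound to a carbonyl carbon. Within the data shown here, no measured pair shows this change, so the expectation in this assay starts from compound 2 at 90 nM and is for no step beyond the scatter, leaning slightly to a higher number. The estimate is a 1.3-fold higher number from compound 2 to compound 3 (0.12 log units; within the scatter) for this step. Compound 3 is expected at 120 nM with a range from 40 nM to 350 nM as estimated.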

Compound 3, half-maximal inhibitory concentration: 20 nM
Compound 3: the middle estimate sits 6.0-fold (0.78 log units) above what was measured, outside the stated range (below it).
By their numbers in this assay, from the lowest: compound 3; then compound 2; then compound 1.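

In this assay, hydroxy in place of hydrogen on a saturated chain carbon bound to a carbonyl carbon gives a 4.5-fold lower number from compound 2 to compound 3 (0.65 log units; beyond the scatter), a step beyond the scatter. Among these compounds, the earlier compounds offered no pair differing at this place, so this is the first sign that the acetamido methyl can be changed, and that methyl to hydroxymethyl lowers the number rather than raising it. Nothing at hand accounts for the gain. As far as these compounds go, whether a methoxy group, a carboxylic acid or a longer hydroxyalkyl chain on this carbon would act likewise remains open.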